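The source may hold more compounds than are shown below. What is called first, only, known or untested is meant among the compounds shown, and "the series" means these compounds.

In a functional assay on MCF7 cells (Homo sapiens) for antiproliferative activity, read by MTT assay, with a stated time of 24 h (a higher number here means a weaker inhibitor, a lower number a stronger inhibitor), compound 3 `CCCC(O)(C#Cc1ccc(C(CC)(CC)C2=CCC(C(=O)NCCN(CC)CC)N2CC)cc1C)CCC` gives 1360 nM, within the scatter of compound 1 `CCN(CC)CCNC(=O)C1CC(C(CC)(CC)c2ccc(C#CC(O)C3CCC3)c(C)c2)=CN1CC` at 1280 nM. Going by the values given here, compound 2 `CCN(CC)CCNC(=O)C1CC=C(C(CC)(CC)c2ccc(C#CC(C)(O)CC)c(C)c2)N1CC` gives 600 nM, and a 2.3-fold higher number from compound 2 to compound 3 (0.36 log units; beyond the scatter) is the only measured step at this triple-bonded carbon, a modest one beyond the scatter. Compound 4 `CCN(CC)CCNC(=O)C1CC=C(C(CC)(CC)c2ccc(C#CC(O)C3CCCCC3)c(C)c2)N1CC` differs from compound 3 as follows: a group of 8 heavy atoms (7 carbon, 1 oxygen; one six-membered non-aromatic ring of carbon only) in place of a group of 8 heavy atoms (7 carbon, 1 oxygen; no ring), on a triple-bonded carbon. Among the compounds with values here, no measured step shows cyclohexyl(hydroxy)methyl entering on this core. Compound 1 has a ring in this group but differs in the core as well, and its value of 1280 nM offers no reason to expect a shift in this assay. The expected change is small, within the scatter: a 1.1-fold lower number from compound 3 to compound 4 (0.05 log units; within the scatter). For compound 4 the estimated value is 1200 nM, with an expected range of 550 nM to 2600 nM.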

Compound 4, half-maximal inhibitory concentration: 2790 nM
Compound 4: middle estimate off by 2.3-fold (0.37 log units), on the low side, outside the stated range (above it).
By their numbers in this assay, from the lowest: compound 2; then compounds 1 and 3 (each within the scatter of the next); then compound 4.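

In this assay, the ring carries a cost at this triple-bonded carbon even with the heavy-atom count unchanged: a 2.1-fold higher number from compound 3 to compound 4 (0.31 log units; beyond the scatter). Measured against the 1-hydroxy-1-methylpropyl group, cyclohexyl(hydroxy)methyl gives a 4.7-fold higher number from compound 2 to compound 4 (0.67 log units; beyond the scatter), so on the shared core the smallest group of the three still gives the lowest number. No evidence on the cause accompanies these values. On these data alone, compound 1 carries a smaller ring on a different core, so ring size on the shared core remains open. Also open, as far as these compounds go, is how a phenyl ring or an amine in this group would read.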